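Replacing a butyl with an amino group

The source may hold more compounds than are shown below. What is called first, only, known or untested is meant among the compounds shown, and "the series" means these compounds.

Compound 1 `CCCCc1ccc(-c2ccc(-c3cc(C(=O)O)c4cc(N)ccc4n3)o2)cc1` gives "not active" (no number reported)
Compound 2 `CCCCc1ccc(-c2ccc(-c3cc(C(=O)O)c4cc(NC(C)=O)ccc4n3)o2)cc1` gives "not active" (no number reported)
Compound 3 `CCCCc1ccc(-c2ccc(-c3cc(C(=O)O)c4cc([N+](=O)[O-])ccc4n3)o2)cc1` gives 463 nM

Among the compounds tested in a functional assay on BJAB cells (Homo sapiens) for cytotoxicity, read by luminescence and CellTiter-Glo, with a stated time of 72 h (on this read-out higher numbers stand for an effect only at larger amounts of compound and lower numbers for an effect already at smaller amounts), only compound 3 gives a number (463 nM). It therefore stands alone, with no second number to rank it against. Among the compounds with values here, no two measured compounds differ in just one place, so no measured step can guide the next one.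

The next compound is compound 4 `Nc1ccc(-c2ccc(-c3cc(C(=O)O)c4cc([N+](=O)[O-])ccc4n3)o2)cc1`, which differs from compound 3 in one place (amino in place of butyl on an aromatic carbon). The change is amino in place of butyl on an aromatic carbon, 4-butylphenyl to 4-aminophenyl. All three measured compounds carry the butyl, so the data show nothing directly about losing it. Within the data shown here, the only number, from compound 3 (463 nM), was obtained with the butyl present, and a reading without a number is a real possibility here. The estimated step of an 11-fold higher number from compound 3 to compound 4 (1.03 log units; beyond the scatter) is expected to be large and towards higher numbers, which would mean a weaker effect, beyond the usual scatter. For compound 4 the expected value is 5000 nM (estimated range 1200 nM to 20000 nM).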

Compound 4, half-maximal effective concentration: "not active" (no number reported)
Compound 4 has no reported number here; there is nothing to compare the estimate with.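

Compound 4 gives no number in this assay, so the step from compound 3 cannot be read. No measured evidence bears on this result. The compounds shown leave open how far the change from 4-butylphenyl to 4-aminophenyl alone shifts the effect.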